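Taking chlorines off compound 2: what to expect of compound 3

The source may hold more compounds than are shown below. What is called first, only, known or untested is meant among the compounds shown, and "the series" means these compounds.

Compound 1 `CCCN1CCN(c2ccc(S(=O)(=O)Oc3ccccc3C)cc2)C1=O`: > 100000 nM (a limit of the assay)
Compound 2 `CCCN1CCN(c2ccc(S(=O)(=O)Oc3c(Cl)cc(Cl)cc3Cl)cc2)C1=O`: 56000 nM

Both results come from a functional assay on M21 cells (Homo sapiens) for antiproliferative activity, read by sulforhodamine B assay, with a stated time of 48 h; a higher number here means a weaker inhibitor, a lower number a stronger inhibitor. Among the measured compounds shown here, compound 2 gives 56000 nM, the only actual number so far. Compound 3 `CCCN1CCN(c2ccc(S(=O)(=O)Oc3cccc(Cl)c3)cc2)C1=O` differs from it on an oxygen: 3-chlorophenyl in place of 2,4,6-trichlorophenyl on an oxygen. For the measured compounds named here, the one measured step at this place is an at least 1.7-fold lower number from compound 1 to compound 2 (0.25 log units; that floor lies within the scatter), and since its floor lies within the scatter, it is only a faint guide. A small move towards a higher number is therefore expected, probably not beyond the scatter, and the assay limit may be reached. The expected step is a 1.3-fold higher number from compound 2 to compound 3 (0.13 log units; within the scatter). For compound 3 the estimated value is 75000 nM, with an expected range of 28000 nM to 150000 nM.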

Compound 3, half-maximal inhibitory concentration: 8600 nM
Compound 3: the middle estimate sits 8.7-fold (0.94 log units) above what was measured; the measured number lies below the stated range.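

In this assay, the group on this oxygen proves able to shift the read-out well beyond the scatter: 3-chlorophenyl in place of 2,4,6-trichlorophenyl gives a 6.5-fold lower number from compound 2 to compound 3 (0.81 log units; beyond the scatter). Set against 2-methylphenyl, the same group gives an at least 11-fold lower number from compound 1 to compound 3 (1.06 log units; beyond the scatter). That second step is only a floor, as compound 1 sits at a limit rather than a number: the limit of > 100000 nM in this assay, at which 1 of the 3 values shown sits.

The step from compound 2 removes chlorines and changes where chlorine sits at once, and the compounds shown do not separate the two. On these data alone, how a phenyl without chlorine, or one carrying an amine or a methoxy group, would read also remains open.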